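A few compounds are considered here, and "the series" means these few. Any claim that something is new, unique, unknown or untested is made for them only; others in the source may bear on it.

Compound 1 `CCCCOc1ccc(C[C@H]2C(=O)OC[C@@H]2Cc2ccccc2)cc1` is measured in a functional assay on HL-60 cells (Homo sapiens) for cytotoxicity, read by WST assay, with a stated time of 48 h (a higher number here means that more compound is needed for the effect, a lower number that less compound is needed), and gives 23000 nM. Compound 2 `CCCCCCCOc1ccc(C[C@H]2C(=O)OC[C@@H]2Cc2ccccc2)cc1` carries propyl in place of hydrogen on a saturated chain carbon, four bonds along the chain from an oxygen on an aromatic ring and in this assay gives only a limit, > 100000 nM. That change made a step of an at least 4.3-fold higher number from compound 1 to compound 2 (0.63 log units; beyond the scatter), read against (the limit of > 100000 nM in this assay, at which 1 of the 3 values shown sits). Compound 3 `COc1cc(C[C@H]2C(=O)OC[C@@H]2Cc2ccccc2)ccc1O` gives 93000 nM in this assay; the difference between its core and the core of compound 1 is not broken down here. Compound 4 `CCCCOc1cc(C[C@H]2C(=O)OC[C@@H]2Cc2ccccc2)ccc1O` carries propyl in place of hydrogen on a saturated chain carbon bound to an oxygen on an aromatic ring, the same kind of change as before, though here the carbon is bound to the oxygen on the aromatic ring rather than four bonds along the chain from it. The step to compound 4 is expected to be a 1.0-fold lower number from compound 3 to compound 4 (0.01 log units; within the scatter), resting on the earlier at least 4.3-fold higher number from compound 1 to compound 2 (0.63 log units; beyond the scatter). Compound 4 is accordingly estimated at 90000 nM in this assay.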

Compound 4, half-maximal effective concentration: 35000 nM
Compound 4: the middle estimate sits 2.6-fold (0.41 log units) above what was measured, and the stated range covers the measured number.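

Lengthening methoxy to butoxy gives a 2.7-fold lower number from compound 3 to compound 4 (0.42 log units; beyond the scatter) in this assay. The same propyl change therefore does not carry over with one outcome in this series, as the two steps run in opposite directions: the same change on two cores in this assay, an at least 4.3-fold higher number (0.63 log units; beyond the scatter) from compound 1 to compound 2 and a 2.7-fold lower number (0.42 log units; beyond the scatter) from compound 3 to compound 4, at least 11-fold (1.06 log units) apart, beyond the scatter of two such steps. Going by these compounds, the earlier step ends at a limit rather than a number, so its full size is unknown, and the two steps do not show whether the core or the place on the chain accounts for the gap: the limit of > 100000 nM in this assay, at which 1 of the 4 values shown sits.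

On these data alone, it remains open how a longer chain in place of butoxy on compound 4 would read in this assay. An amine or a carboxylic acid at the end of that chain also remains untested among the compounds shown here.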